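Benzylamino in place of pyrrolidin-1-yl on a shared core

The source may report more compounds than this note shows. Statements on the series, on what has been measured and on what is new or still open speak of the compounds shown alone.

Compound 1 `CCCCc1oc2ccccc2c1C(=O)c1ccc(OCC(=O)N2CCCC2)cc1`: 42400 nM
Compound 2 `CCCCc1oc2ccccc2c1C(=O)c1ccc(OCC(=O)N2CCN(C(=O)OC(C)(C)C)CC2)cc1`: 42200 nM

Only these two compounds have been measured in a functional assay on MCF7 cells (Homo sapiens) for antiproliferative activity, read by MTT assay, with a stated time of 24 h; a higher number here means a weaker inhibitor, a lower number a stronger inhibitor. There, compound 1 gives 42400 nM and compound 2 gives 42200 nM. For the measured compounds named here, the two values lie within the scatter of each other, so compound 1 stands level with the only other compound measured.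

Compound 3 `CCCCc1oc2ccccc2c1C(=O)c1ccc(OCC(=O)NCc2ccccc2)cc1` keeps the core of compound 1 and carries benzylamino in place of pyrrolidin-1-yl on a carbonyl carbon. Going by the values given here, no measured pair isolates this change, so the data give no direct guide to its size. With nothing pointing either way, no step beyond the scatter is expected in this assay, and no firm direction. The expected change is a 1.2-fold lower number from compound 1 to compound 3 (0.07 log units; within the scatter). For compound 3 the estimated value is 36000 nM, with an expected range from 14000 nM to 85000 nM.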

Compound 3, half-maximal inhibitory concentration: 19600 nM
Beside the measured number, compound 3's estimate is 1.8-fold (0.26 log units) above it; low and high end bracket the measured number.
By their numbers in this assay, from the lowest: compound 3; then compounds 2 and 1 (each within the scatter of the next).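

Benzylamino in place of pyrrolidin-1-yl on a carbonyl carbon gives a 2.2-fold lower number from compound 1 to compound 3 (0.34 log units; beyond the scatter) in this assay and so shows that the number can move with the group at this position, though the step is modest. For the compounds shown here, this is the first measured pair to isolate the change, and it gives the step a direction and a size. Nothing available explains the step or ties it to the six-membered aromatic ring or to the hydrogen-bond donor that enters with benzylamino.

The compounds shown leave open which of those two parts matters, a question that benzyl(methyl)amino, which lacks the amide hydrogen, could address. They also leave open whether phenylamino or the longer 2-phenylethylamino would extend the step, hold it or lose it.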